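Compound 4: an ester change without a measured precedent

A few compounds are considered here, and "the series" means these few. Any claim that something is new, unique, unknown or untested is made for them only; others in the source may bear on it.

In an ADME assay on HepG2 2.2.15 cells (Homo sapiens) for cytotoxicity (on this read-out higher numbers stand for lower toxicity in this test and lower numbers for higher toxicity in this test), compound 3 (`CC(C)C(=O)OCCc1c(-c2ccccc2Cl)c2cc(Cl)ccc2[nH]c1=O`) gives 62000 nM and lies within the scatter of compound 1 (`Cn1c(=O)c(CCO)c(-c2ccccc2Cl)c2cc(Cl)ccc21`) at 34000 nM, while compound 2 (`C=CCn1c(=O)c(CCO)c(-c2ccccc2Cl)c2cc(Cl)ccc21`) at 23000 nM is separated from compound 3 by a gap beyond the scatter in this series. Compound 4 (`COCC(=O)OCCc1c(-c2ccccc2Cl)c2cc(Cl)ccc2[nH]c1=O`) differs from compound 3 by methoxymethyl in place of isopropyl on a carbonyl carbon as methoxymethyl in place of isopropyl on a carbonyl carbon. Within the data shown here, the one measured step is a 1.5-fold lower number from compound 1 to compound 2 (0.17 log units; within the scatter) and does not involve that carbonyl carbon, so no measured step speaks directly to this change. No step beyond the scatter is therefore expected in this assay for this change. The estimated step is a 1.1-fold lower number from compound 3 to compound 4 (0.05 log units; within the scatter) and stays within the scatter. Compound 4 is estimated at 55000 nM with 25000 nM to 100000 nM as the expected range.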

Compound 4, half-maximal cytotoxic concentration: 74000 nM
Compound 4: the middle estimate sits 1.3-fold (0.13 log units) below what was measured; low and high end bracket the measured number.
By their numbers in this assay, from the lowest: compounds 2, 1, 3 and 4 (each within the scatter of the next, the first and the last beyond it).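

In this assay, among these compounds, methoxymethyl in place of isopropyl on a carbonyl carbon gives a 1.2-fold higher number from compound 3 to compound 4 (0.08 log units; within the scatter), the first measured step at this carbonyl carbon. The ester position therefore accepts an oxygen-bearing group of the same heavy-atom size as isopropyl without a step beyond the scatter, though this rests on a single pair.

On these data alone, whether an amine, a carboxylic acid or a longer chain on this carbonyl carbon would also stay within the scatter remains open. No available measurement explains the size of this step.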